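Swapping the Bromophenyl for a Nitrophenyl on the Shared Core

The source may report more compounds than this note shows. Statements on the series, on what has been measured and on what is new or still open speak of the compounds shown alone.

Compound 1, `CC1=C(C(=O)Nc2ccc([N+](=O)[O-])cc2)C(c2ccc(Br)cc2)N=C(SCc2ccccc2)N1`: 2.1%
Compound 2, `CC1=C(C(=O)Nc2ccc([N+](=O)[O-])cc2)C(c2ccc(Br)cc2)N=C(SCc2ccc(Cl)cc2)N1`: 3.1%

Both compounds were tested in a functional assay on the whole organism (artery, strain albino) with Rattus norvegicus as the target, with a stated time of 15 min, at a dose of 10 mg/kg by the oral route; a lower number here means less inhibition, a higher number more inhibition at the dose given (going by the name of the read-out). Within the data shown here, compound 1 stands lowest of the two numbers, and the one measured step, a number 1 percentage points higher from compound 1 to compound 2 (within the scatter), is within the scatter, so the two compounds cannot be told apart on this read-out.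

Compound 3, `CC1=C(C(=O)Nc2ccc([N+](=O)[O-])cc2)C(c2cccc([N+](=O)[O-])c2)N=C(SCc2ccccc2)N1`, differs from compound 1 by 3-nitrophenyl in place of 4-bromophenyl on a saturated ring carbon. Among the measured compounds shown here, the only measured step concerns the benzylsulfanyl group, a different part of the shared core, so no measured step bears on this change, and the measured numbers give no hint of a large movement. The step expected is therefore a number 0.9 percentage points higher from compound 1 to compound 3 (within the scatter), nothing beyond the scatter. The estimate for compound 3 in this assay is 3%, with a range from 0% to 12%.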

Compound 3, a percentage reported as inhibition, in the whole organism at one dose (the size of the read-out at that dose, not a potency): 2.6%
For compound 3 the middle estimate is 0.4 percentage points above the measured one; the measured number falls inside the stated range.
By their numbers in this assay, from the lowest: compounds 1, 3 and 2 (each within the scatter of the next).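

Among these compounds, this is the first look at the aryl group on the saturated ring carbon, since the earlier step touched only the benzylsulfanyl group. In this assay, the exchange of 4-bromophenyl for 3-nitrophenyl gives a number 0.5 percentage points higher from compound 1 to compound 3 (within the scatter), so this read-out does not separate the two groups at this position, even though the substituent on the ring and its place both differ. No measurement here offers an explanation for this lack of a visible difference.

Still open, going by these compounds, is whether a group of another kind at this ring carbon, such as an amine, a carboxylic acid or a longer alkyl chain, would move the number beyond the scatter. A single exchange also cannot show what the nitro group and its place on the ring each contribute alone.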